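The source may hold more compounds than are shown below. What is called first, only, known or untested is meant among the compounds shown, and "the series" means these compounds.

Of the compounds shown here, three have so far been measured in a functional assay on MCF7 cells (Homo sapiens) for cytotoxicity, read by MTT assay, with a stated time of 72 h; on this read-out higher numbers stand for weaker inhibition and lower numbers for stronger inhibition. Compound 1 `N/C(=N\NC(=S)N1CCCCCC1)c1ccccn1` gives 2600 nM, compound 2 `N/C(=N\NC(=S)N1CCCCC1)c1ccccn1` gives 8500 nM, and compound 3 `Cc1cccc(/C(N)=N/NC(=S)N2CCCCC2)n1` gives 74000 nM. Compound 1 stands lowest of the three in this assay, with compound 2 nearest to it and compound 3 furthest from it. The difference between the cores of compound 1 and compound 2 is not broken down here. Compound 3 differs from compound 2 in one place: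

methyl in place of hydrogen on an aromatic carbon

That change made a step of an 8.7-fold higher number from compound 2 to compound 3 (0.94 log units; beyond the scatter). Compound 4 `Cc1ccnc(/C(N)=N/NC(=S)N2CCCCCC2)c1` has not yet been measured in this assay; it differs from compound 1 in one place:

methyl in place of hydrogen on an aromatic carbon

Going by the values given here, this is the same kind of change as the one from compound 2 to compound 3, but not the same: in compound 3 the methyl sits next to the ring nitrogen, whereas in compound 4 it sits opposite the ring nitrogen, in both cases meta to a large group. Compound 4 is expected to show a step of a 3.5-fold higher number from compound 1 to compound 4 (0.54 log units; beyond the scatter) in this assay, somewhat smaller than the earlier one, because an 8.7-fold higher number from compound 2 to compound 3 (0.94 log units; beyond the scatter) arose from the same kind of change at a place that is not the same. Compound 4 is therefore estimated at 9000 nM, plausibly between 3000 nM and 40000 nM.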

Compound 4, half-maximal inhibitory concentration: 6900 nM
Compound 4: the middle estimate sits 1.3-fold (0.12 log units) above what was measured; measured number inside the range.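

In this assay methyl in place of hydrogen on an aromatic carbon again gives a higher number, a step of a 2.7-fold higher number from compound 1 to compound 4 (0.42 log units; beyond the scatter) on the core of compound 1, so the direction of the change is the same on both cores shown, but its size does not carry over unchanged: the same change on two cores in this assay, an 8.7-fold higher number (0.94 log units; beyond the scatter) from compound 2 to compound 3 and a 2.7-fold higher number (0.42 log units; beyond the scatter) from compound 1 to compound 4, 3.3-fold (0.52 log units) apart, beyond the scatter of two such steps

The two steps differ in more than the core, since the methyl sits opposite the ring nitrogen in compound 4 and at another place on the ring in compound 3, so this pair cannot show whether the core or the place sets the size of the step. Two steps also make no general rule for this series, and they do not explain the gap between them.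

The compounds shown leave open what the methyl does at one and the same place on both cores. They also leave open whether a group other than methyl on this ring, such as methoxy, chlorine or an amine, would move the number in the same direction.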